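The source may report more compounds than this note shows. Statements on the series, on what has been measured and on what is new or still open speak of the compounds shown alone.

Working notes on the arylpiperazine series in an assay for displacement of a labelled ligand from Adrenergic receptor alpha-1 (Rattus norvegicus), read by scintillation counting, with a stated time of 30 min; on this read-out higher numbers stand for weaker inhibition and lower numbers for stronger inhibition.

Compound 1 `COc1ccccc1N1CCN(CCCN/C(=N\C#N)c2ccncc2)CC1` in this assay gives only a limit, > 10000 nM, not a number (the limit of > 10000 nM in this assay, at which 1 of the 3 values shown sits). Compound 2 `CCOc1ccccc1N1CCN(CCCN/C(=N\C#N)c2ccncc2)CC1` gives 190 nM, and compound 3 `N#C/N=C(\NCCCN1CCN(c2cccc(Cl)c2)CC1)c1ccncc1` gives 912 nM. Among the numbers shown compound 3 stands highest, its nearest neighbour being compound 2, from which it is set apart by a 4.8-fold higher number from compound 2 to compound 3 (0.68 log units; beyond the scatter). The ring on the piperazine nitrogen is the only part varied: an at least 52-fold lower number from compound 1 to compound 2 (1.72 log units; beyond the scatter), and an at least 10-fold lower number from compound 1 to compound 3 (1.04 log units; beyond the scatter), both beyond the scatter.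

Compound 4 `N#C/N=C(\NCCCN1CCN(c2ccccn2)CC1)c1ccncc1` is not yet measured. It differs from compound 3 by pyridin-2-yl in place of 3-chlorophenyl on an amine nitrogen in a ring. Within the data shown here, no measured step swaps a carbon-only aromatic ring for a nitrogen-containing one on this position, so the three steps above bear on it only in showing that this ring governs the read-out and that changes here have run from modest to large. Among the measured compounds shown here, with no closer precedent, compound 4 is expected near compound 3 or somewhat higher, an expected step of a 2.2-fold higher number from compound 3 to compound 4 (0.34 log units; beyond the scatter) in this assay. The estimate for compound 4 is 2000 nM, expected to fall between 400 nM and 8000 nM, with some chance that only a limit is returned.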

Compound 4, inhibition constant: > 10000 nM
Compound 4: no number, only a limit; the forecaster's own chance of this, stated with the estimate: 20%; middle value at least 5.0-fold (0.69 log units) away from the limit.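

In this assay this position, on an amine nitrogen in a ring, now shows that a ring with a hetero atom can cost far more than any change among the readable compounds: pyridin-2-yl gives a sharp loss against 3-chlorophenyl (an at least 10-fold higher number from compound 3 to compound 4 (1.04 log units; beyond the scatter)) and against 2-ethoxyphenyl (an at least 52-fold higher number from compound 2 to compound 4 (1.72 log units; beyond the scatter)). This is no plain split by ring type, for compound 1, which carries a carbon-only 2-methoxyphenyl ring, also returns only a limit, and the step between compound 1 and compound 4 cannot be read, since both values are limits. The top of the range now holds two quite different rings, and the true distance between them stays hidden: (the limit of > 10000 nM in this assay, at which 2 of the 4 values shown sit).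

Open, as far as these compounds go, is whether pyridin-3-yl or pyrimidin-2-yl on this nitrogen would also stay at the limit, or whether an ethoxy group on the pyridin-2-yl ring would bring back a measurable number. Also open, from the compounds shown here alone, is whether a longer chain in the shared core would change the picture for compound 4.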